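The compounds below may be only part of what the source reports. "The series", "measured", "known", "first", "only" and "open" are said of these compounds alone.

Measured compounds:
- compound 1, `COc1cccc(NC(=O)Oc2cc(=O)n(CCCO)c3c2CC(CC=C(C)C)C(C)(C)C3)c1`, 0%
- compound 2, `COc1ccccc1NC(=O)Oc1cc(=O)n(CCCO)c2c1CC(CC=C(C)C)C(C)(C)C2`, 0%

In a functional assay on PANC-1 cells (Homo sapiens) for inhibition, read by MTT assay, with a stated time of 24 h, tested at 10 uM (on this read-out lower numbers stand for less inhibition and higher numbers for more inhibition at the one concentration tested (going by the name of the read-out)), compound 1 gives 0%, and compound 2 gives 0%. The step of no change at the digits printed from compound 1 to compound 2 (within the scatter) shows that moving a methoxy group from one position on the phenyl ring to another left the read-out where it was, and compound 2 therefore stands level with compound 1 on these numbers, at the floor of the scale.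

The next compound, compound 3, has the structure `CC(C)=CCC1Cc2c(OC(=O)Nc3cccc(F)c3)cc(=O)n(CCCO)c2CC1(C)C`. It differs from compound 2 in one place: 3-fluorophenyl in place of 2-methoxyphenyl on an amide-type nitrogen.

Among the compounds with values here, only one measured step bears on this change, and it is a change on the same phenyl ring that produced no movement. Within the data shown here, no measured step swaps a methoxy group for a fluorine, so the expectation rests on the two measured values alone, both of which sit at the floor. For compound 3 the expected step is a number 3 percentage points higher from compound 2 to compound 3 (within the scatter), that is, no change beyond the scatter. Compound 3 is therefore estimated to give 3% in this assay, with a range from 0% to 15%.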

Compound 3, a percentage reported as inhibition, at one concentration (the size of the read-out at that concentration, not a potency): 0%
Estimate against measurement, compound 3: 3 percentage points above; low and high end bracket the measured number.
By their numbers in this assay, from the lowest: compounds 1, 2 and 3 (each within the scatter of the next).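

In this assay, replacing the 2-methoxyphenyl group with 3-fluorophenyl on the amide-type nitrogen gives no change at the digits printed from compound 2 to compound 3 (within the scatter), and fluoro in place of methoxy on an aromatic carbon gives no change at the digits printed from compound 1 to compound 3 (within the scatter). The earlier pair showed only a methoxy group changing its place on the ring, whereas here the substituent itself changes, and a group with 1 hydrogen-bond acceptor gives way to one with 0 without any movement in the read-out. All three compounds sit at the bottom of the scale, so these steps show that none of the three aryl groups gives measurable inhibition at the one concentration tested, and no separate data offer an explanation for that.

These compounds leave open whether any group at this position can lift the read-out off the bottom of the scale. An amine or a carboxylic acid on the phenyl ring, or a longer chain in place of that ring, would test this, as would changes elsewhere on the shared core.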